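Exchanging the Aromatic Ring Substituent of Compound 1

The source may hold more compounds than are shown below. What is called first, only, known or untested is meant among the compounds shown, and "the series" means these compounds.

Compound 1 `CN1CCN(c2ccc(C3=NN(C(=O)CCCl)C(c4ccc(N(C)C)cc4)C3)cc2)CC1` is the one of the two measured compounds with the lower number. In a functional assay on NCI-H1975 cells (Homo sapiens) for inhibition, read by sulforhodamine B assay, tested at 10 uM (a lower number here means less inhibition, a higher number more inhibition at the concentration tested (going by the name of the read-out)), compound 1 gives -0.2%, the lowest of the two numbers seen so far. Compound 2 `CN1CCN(c2ccc(C3=NN(S(=O)(=O)c4ccc(C#N)cc4)C(c4ccc(N(C)C)cc4)C3)cc2)CC1` gives 100% in this assay; the large step of a number 100.2 percentage points higher from compound 1 to compound 2 (beyond the scatter) comes from placing (4-cyanophenyl)sulfonyl in place of (2-chloroethyl)carbonyl on an amine nitrogen in a ring. Compound 3 `CN(C)c1ccc(C2CC(c3ccc(-n4ccnc4)cc3)=NN2C(=O)CCCl)cc1` keeps the (2-chloroethyl)carbonyl group of compound 1 and changes instead the group on an aromatic carbon, para to a large group: 1H-imidazol-1-yl in place of 4-methylpiperazin-1-yl on an aromatic carbon. Going by the values given here, the only measured step concerns the amine nitrogen in a ring, not the aromatic carbon, so no measured step tells how this exchange would shift this assay. With nothing in the measured compounds to rest on, the step of a number 5.2 percentage points higher from compound 1 to compound 3 (within the scatter) is expected to be none beyond the scatter, and compound 3 is expected to stay near compound 1. Compound 3 is therefore estimated at 5% in this assay, within a range from -10% to 30%.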

Compound 3, a percentage reported as inhibition, at one concentration (the size of the read-out at that concentration, not a potency): -2.5%
Compound 3: the middle estimate sits 7.5 percentage points above what was measured, and the stated range covers the measured number.
By their numbers in this assay, from the lowest: compounds 3 and 1 (each within the scatter of the next); then compound 2.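

The exchange at this position, on an aromatic carbon para to a large group, gives a number 2.3 percentage points lower from compound 1 to compound 3 (within the scatter) in this assay, so replacing the six-membered non-aromatic ring of 4-methylpiperazin-1-yl with the five-membered aromatic ring of 1H-imidazol-1-yl leaves the two compounds indistinguishable. Going by these compounds alone, this is the first reading at this position, as the earlier step, a number 100.2 percentage points higher from compound 1 to compound 2 (beyond the scatter), concerned the group on the amine nitrogen in a ring; with (2-chloroethyl)carbonyl on that nitrogen, neither group on the aromatic carbon gives inhibition beyond the scatter of zero, with compound 1 at -0.2% and compound 3 at -2.5%. No available evidence explains why this exchange leaves the read-out where it was.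

The compounds shown leave open whether 1H-imidazol-1-yl and 4-methylpiperazin-1-yl would also match when (4-cyanophenyl)sulfonyl sits on the ring nitrogen, as it does in compound 2, where inhibition is high enough for a difference to appear. They also leave open how a morpholine ring, a simple primary amine or a carboxylic acid on the same aromatic carbon would read in this assay.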